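The source may hold more compounds than are shown below. What is called first, only, known or untested is meant among the compounds shown, and "the series" means these compounds.

Two compounds of the shared core of compound 1 `CCN1CCN(c2nc(/C=C/c3cc(OC)c(OC)c(OC)c3)nc3ccsc23)CC1` have been measured in a functional assay on L02 cells (Homo sapiens) for inhibition, read by Griess assay, with stated times of 1 h and 24 h; a higher number here means a weaker inhibitor, a lower number a stronger inhibitor. Compound 1 gives only a limit of the assay, > 1000000 nM. Within the data shown here, compound 2 `COc1cc(/C=C/c2nc(N(C)c3ccccc3)c3sccc3n2)cc(OC)c1OC` gives 767000 nM, the only actual number in this assay, so compound 2 stands as the sole measured point. Among the measured compounds shown here, the single measured step, an at least 1.3-fold lower number from compound 1 to compound 2 (0.11 log units; that floor lies within the scatter), comes with methyl(phenyl)amino in place of 4-ethylpiperazin-1-yl on an aromatic carbon, and it rests on (the limit of > 1000000 nM in this assay, at which 1 of the 2 values shown sits), so its true size is unknown.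

Compound 3 `COc1cc(/C=C/c2nc(OCc3ccccc3)c3sccc3n2)cc(OC)c1OC` differs from compound 2 by benzyloxy in place of methyl(phenyl)amino on an aromatic carbon. For the measured compounds named here, no measured step concerns benzyloxy, and the one step known starts from a limit, so it gives no guide to direction. The change keeps the same number of heavy atoms and the same count of donors and acceptors. Compound 3 is therefore expected to stay close to compound 2, with a step of a 1.0-fold lower number from compound 2 to compound 3 (0.01 log units; within the scatter) in this assay, none beyond the scatter. The estimate for compound 3 is 750000 nM, within 250000 nM to 2000000 nM.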

Compound 3, half-maximal inhibitory concentration: > 1000000 nM
Compound 3: no number, only a limit; the forecaster's own chance of this, stated with the estimate: 40%; middle value at least 1.3-fold (0.12 log units) from the limit.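

With benzyloxy on this aromatic carbon, next to the ring nitrogen, compound 3 gives only a limit in this assay, so this position now holds two groups that yield no actual number, benzyloxy and 4-ethylpiperazin-1-yl. The readable step is an at least 1.3-fold higher number from compound 2 to compound 3 (0.11 log units; that floor lies within the scatter), and since its floor lies within the scatter, it does not establish a real loss on replacing methyl(phenyl)amino with a group of the same counts of heavy atoms, donors and acceptors; the step between compound 1 and compound 3 cannot be read. Compound 2 therefore remains the only compound with an actual number, and every comparison at this position rests on a limit: the limit of > 1000000 nM in this assay, at which 2 of the 3 values shown sit.

From the compounds shown here alone, the true size of the difference between methyl(phenyl)amino and benzyloxy stays open, and so does whether any group at this position can give a clearly lower number than compound 2. Neither phenylamino, which lacks the methyl on the nitrogen, nor a small group such as methoxy or dimethylamino is among the compounds shown, so the roles of the methyl and the phenyl ring remain unresolved.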